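The source may report more compounds than this note shows. Statements on the series, on what has been measured and on what is new or still open speak of the compounds shown alone.

Measured so far in a functional assay on HeLa cells (Homo sapiens) for inhibition, read by MTT assay, with a stated time of 24 h; on this read-out higher numbers stand for weaker inhibition and lower numbers for stronger inhibition:
compound 1 `CCOC(=O)C1=Cc2ccccc2OC1(OCc1cc(-c2ccc(F)cc2F)no1)C(F)(F)F`: > 150000 nM, a limit of the assay
compound 2 `CCOC(=O)C1=Cc2ccccc2OC1(OCc1cn(CC(=O)Nc2cccc(Cl)c2)nn1)C(F)(F)F`: 12300 nM
compound 3 `CCOC(=O)C1=Cc2ccccc2OC1(OCc1cc(-c2ccc(OC)cc2)no1)C(F)(F)F`: > 150000 nM, a limit of the assay

For the measured compounds named here, compound 2 stands as the only member of the series with a read number in this assay; the two other values shown are limits. Because both compound 1 and compound 3 sit at the limit of > 150000 nM in this assay, at which 2 of the 3 values shown sit, the step that the two limits leave unreadable from compound 1 to compound 3 cannot be read. Compound 4 `CCOC(=O)C1=Cc2ccccc2OC1(OCc1cn(-c2ccc([N+](=O)[O-])cc2)nn1)C(F)(F)F` is not yet measured. It differs from compound 2 by 4-nitrophenyl in place of ((3-chlorophenyl)carbamoyl)methyl on an aromatic nitrogen. Going by the values given here, no measured pair varies the group on the aromatic nitrogen of the five-membered ring with three nitrogens, so no measured step bears on this change, and the read number of compound 2 is the only anchor. A value near that of compound 2 is expected for compound 4, with a 1.6-fold higher number from compound 2 to compound 4 (0.21 log units; within the scatter). The estimate for compound 4 is 20000 nM, between 5000 nM and 150000 nM. A limit rather than a number is also a real possibility.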

Compound 4, half-maximal inhibitory concentration: > 150000 nM
Compound 4: a limit, no number (the forecaster's own chance of this, stated with the estimate: 35%); middle value at least 7.5-fold (0.87 log units) away from the limit.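

Replacing ((3-chlorophenyl)carbamoyl)methyl with 4-nitrophenyl on the aromatic nitrogen gives an at least 12-fold higher number from compound 2 to compound 4 (1.08 log units; beyond the scatter) in this assay. For the compounds shown here, this is the first measured step at this position, and it shows that the group on that nitrogen can decide whether a number is read at all, so the read number of compound 2 does not carry over to another group there. The value of compound 4 is a limit, so the step gives only a minimum size, and compound 4 joins the compounds without a number: the limit of > 150000 nM in this assay, at which 3 of the 4 values shown sit.

Which part of the change matters stays open, as the carbamoyl link, the amide hydrogen and the ring substituent all change together. A plain phenyl on that nitrogen, or the same carbamoyl link ending in a short alkyl chain, would separate these parts.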